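Swapping Bromine for Chlorine on Two Related Cores

The source may hold more compounds than are shown below. What is called first, only, known or untested is meant among the compounds shown, and "the series" means these compounds.

Compound 1 `COC(=O)[C@@]1(C)CCC=C2[C@@H]1CC[C@@H](C)[C@]2(C)Cc1c[nH]c2c(Br)cccc12` and compound 2 `COC(=O)[C@@]1(C)CCC=C2[C@@H]1CC[C@@H](C)[C@]2(C)Cc1c[nH]c2c(Cl)cccc12` share one core and differ at a single halogen. In a functional assay on A549 cells (Homo sapiens) for inhibition, read by sulforhodamine B assay, with a stated time of 48 h (a higher number here means a weaker inhibitor of growth, a lower number a stronger inhibitor of growth), compound 1 gives 22000 nM, and compound 2 gives 22000 nM. The change between them is chloro in place of bromo on an aromatic carbon, and it made the step of no change at the digits printed from compound 1 to compound 2 (within the scatter).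

Compound 3 `COC(=O)[C@@]1(C)CC[C@@H]2C3=C1CC[C@@H](C)[C@]3(C)C[C@@H]1c3cccc(Br)c3N[C@H]21` is built from the same atoms as compound 1, joined differently; how the two cores differ is not broken down here. In this assay compound 3 gives 42000 nM, a number within the usual scatter of those of compound 1 and compound 2.

Compound 4 `COC(=O)[C@@]1(C)CC[C@@H]2C3=C1CC[C@@H](C)[C@]3(C)C[C@@H]1c3cccc(Cl)c3N[C@H]21` carries the same kind of change relative to compound 3: chloro in place of bromo on an aromatic carbon. The surroundings are not identical, since in compound 1 the aromatic ring belongs to a fused or bridged system of two rings, while in compound 3 it belongs to one of five rings. Because the step of no change at the digits printed from compound 1 to compound 2 (within the scatter) stayed within scatter, the step from compound 3 to compound 4 is expected to be small as well, no change at the digits printed from compound 3 to compound 4 (within the scatter). Compound 4 is therefore estimated at 42000 nM in this assay, with an expected range from 21000 nM to 84000 nM.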

Compound 4, concentration for 50% growth inhibition: 54000 nM
Compound 4: middle estimate off by 1.3-fold (0.11 log units), on the low side, and the stated range covers the measured number.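

Going from bromo to chloro on the core of compound 3 gave a 1.3-fold higher number from compound 3 to compound 4 (0.11 log units; within the scatter) in this assay. Set beside the earlier step on the core of compound 1, the same swap carried over from one core to the other without a difference that can be told from noise: the same change on two cores in this assay, no change at the digits printed (within the scatter) from compound 1 to compound 2 and a 1.3-fold higher number (0.11 log units; within the scatter) from compound 3 to compound 4, 1.3-fold (0.11 log units) apart, within the scatter of two such steps This shows only that exchanging these two halogens changes little on these two cores in this one assay; it does not show that the swap would stay as small on a third core or in another assay, or that any other group at this carbon would carry over in the same way.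

The compounds shown hold only bromo and chloro on this aromatic carbon, which leaves open how fluoro, a methoxy group or an amine would read there. As far as these compounds go, the methyl ester stays the same in all four compounds, so the effect of a carboxylic acid or an amide in its place also remains open.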